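A few compounds are considered here, and "the series" means these few. Any claim that something is new, unique, unknown or untested is made for them only; others in the source may bear on it.

Compounds 1 to 4 share one core and differ only in what sits on a saturated ring carbon. In an ADME assay on microsomes from liver (Homo sapiens) for metabolic stability, read by LC-MS, using NADPH, with stated times of 10 min and 30 min (a higher number here means faster removal of the compound, a lower number slower removal), compound 1 `O=C1c2ccc(Cl)cc2CN1c1cccnc1` gives 12.8 mL/min/kg, and compound 2 `CCC1c2cc(Cl)ccc2C(=O)N1c1cccnc1` gives 6.6 mL/min/kg. Among the measured compounds shown here, the one measured step between such compounds is a 1.9-fold lower number from compound 1 to compound 2 (0.29 log units; within the scatter), where ethyl takes the place of hydrogen on that carbon, so this change shows no clear effect.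

Compound 3 `CC1(C)c2cc(Cl)ccc2C(=O)N1c1cccnc1` gives < 3.5 mL/min/kg, which is a limit of the assay and not a number.

Compound 4 `CC1c2cc(Cl)ccc2C(=O)N1c1cccnc1` comes from compound 3 through (hydrogen in place of methyl on a saturated ring carbon). This places hydrogen in place of methyl on a saturated ring carbon, next to the ring nitrogen. For the measured compounds named here, no step starting from compound 3 has been measured, so only the step with ethyl can serve as a guide. Compound 4 keeps a methyl on the carbon where compound 1 has hydrogen and compound 2 has ethyl, so it is expected to land close to those two, given the small size of a 1.9-fold lower number from compound 1 to compound 2 (0.29 log units; within the scatter). The estimated step is an at least 2.0-fold higher number from compound 3 to compound 4 (0.30 log units; that floor lies within the scatter), towards faster removal, though its true size is uncertain while compound 3 has only a limit. For compound 4 the expected clearance is 7 mL/min/kg, with an estimated range from 4 mL/min/kg to 12 mL/min/kg.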

Compound 4, clearance: 12.2 mL/min/kg
Beside the measured number, compound 4's estimate is 1.7-fold (0.24 log units) below it; the whole stated range lies below it.
By their numbers in this assay, from the lowest: compounds 2, 4 and 1 (each within the scatter of the next). At a limit, below all of these: compound 3.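

In this assay, among the compounds shown here, hydrogen in place of methyl on this saturated ring carbon, next to the ring nitrogen, gives an at least 3.4-fold higher number from compound 3 to compound 4 (0.54 log units; beyond the scatter), the first step that lies beyond the scatter, so the carbon that carries two methyl groups stands apart from those that carry one group or none. With a single group or none on this carbon, the number barely separates: methyl in place of hydrogen gives a 1.0-fold lower number from compound 1 to compound 4 (0.02 log units; within the scatter), and hydrogen in place of methyl on the ethyl chain gives a 1.8-fold higher number from compound 2 to compound 4 (0.27 log units; within the scatter), so hydrogen, methyl and ethyl here cannot be told apart. Compound 3 stands at a limit and not at a number, so the step from it has only a floor: the limit of < 3.5 mL/min/kg in this assay, at which 1 of the 4 values shown sits.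

As far as these compounds go, it remains open whether two ethyl groups on this carbon, or a cyclopropyl ring built on it, would behave like the two methyl groups of compound 3. The compounds shown also leave open what a hydroxyl group or an amine would do on this carbon, and whether the step from methyl to hydrogen would be of similar size with a different group in place of the pyridin-3-yl group.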